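This account rests on a few compounds, and the source may have more. Where it says the series, first, only, none or still open, it means among the compounds named here.

Compound 1 `Oc1nc2ccc(C(F)(F)F)cc2c(O)c1-c1ccccc1` carries a plain phenyl group on the shared core. In an assay on isolated protein for inhibition of fatty acid synthase (Rattus norvegicus) (on this read-out lower numbers stand for stronger inhibition and higher numbers for weaker inhibition), compound 1 gives only a limit of the assay, > 15000 nM, and not a number. Of the three values shown, one sits at such an edge: the limit of > 15000 nM in this assay, at which 1 of the 3 values shown sits. Compound 2 `O=[N+]([O-])c1cc2c(O)c(-c3ccc(Cl)cc3Cl)c(O)nc2cc1Cl`, which carries a nitro group and a 2,4-dichlorophenyl, gives 443 nM in this assay. Compound 3 `O=[N+]([O-])c1cc2c(O)c(-c3ccc(F)cc3F)c(O)nc2cc1Cl`, with a 2,4-difluorophenyl in the same place, gives 173 nM in this assay. Among the two real numbers, compound 3 holds the lower one, and the only measured step, a 2.6-fold lower number from compound 2 to compound 3 (0.41 log units; beyond the scatter), separates it from its nearest neighbour.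

Compound 4 `O=[N+]([O-])c1cc2c(O)c(-c3cc(Cl)cc(Cl)c3)c(O)nc2cc1Cl` differs from compound 3 in a single place: 3,5-dichlorophenyl in place of 2,4-difluorophenyl on an aromatic carbon. Among the measured compounds shown here, the one measured step that bears on this change is a 2.6-fold lower number from compound 2 to compound 3 (0.41 log units; beyond the scatter), where two chlorines gave way to two fluorines and the number fell. For the measured compounds named here, compound 4 returns to two chlorines, now as a 3,5-dichlorophenyl rather than the 2,4-dichlorophenyl of compound 2, an arrangement no measured pair covers, so the size of the effect is uncertain. Compound 4 is therefore expected to give about 400 nM in this assay, with a likely range from 120 nM to 1500 nM. That estimate amounts to a 2.3-fold higher number from compound 3 to compound 4 (0.36 log units; beyond the scatter), a modest rise.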

Compound 4, half-maximal inhibitory concentration: 134 nM
Beside the measured number, compound 4's estimate is 3.0-fold (0.47 log units) above it; low and high end bracket the measured number.
By their numbers in this assay, from the lowest: compounds 4 and 3 (each within the scatter of the next); then compound 2. At a limit, above all of these: compound 1.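

Moving the two chlorines from the 2,4-dichlorophenyl to the 3,5-dichlorophenyl leaves the atoms of the group unchanged and alters only their arrangement on the ring, yet it gives a 3.3-fold lower number from compound 2 to compound 4 (0.52 log units; beyond the scatter), so at this position the arrangement of the halogens matters and not only their identity. The swap between the two halogen patterns that compound 3 and compound 4 carry gives a 1.3-fold lower number from compound 3 to compound 4 (0.11 log units; within the scatter), so fluorine in place of chlorine cannot by itself account for the lower number seen earlier, because the 3,5-dichlorophenyl cannot be told apart from the 2,4-difluorophenyl. Nothing in the data shown gives a reason for either step.

In this assay compound 1, with its plain phenyl, gives > 15000 nM, which is a limit of the assay and not a number. From the compounds shown here alone, compound 1 also differs from the others in more than one place, so the contribution of the halogens alone stays open, as does what a phenyl carrying a single chlorine, a methoxy group or a carboxylic acid would give at this position.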